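The source may report more compounds than this note shows. Statements on the series, on what has been measured and on what is new or still open speak of the compounds shown alone.

Of the compounds shown here, three built on one shared core have been tested in an ADME assay on cells for inhibition of Amine oxidase [flavin-containing] A (Homo sapiens), read by spectrophotometry; a lower number here means a stronger inhibitor, a higher number a weaker inhibitor. Compound 1 `S=C(Nc1ccccc1)Nc1ccc2[nH]ccc2c1` carries no substituent on its outer ring; in this assay compound 1 gives > 30000 nM, which is a limit of the assay and not a number. Compound 2 `Oc1ccc(NC(=S)Nc2ccc3[nH]ccc3c2)cc1` carries a hydroxyl group, and in this assay compound 2 is reported as "not active" (no number reported). Compound 3 `S=C(Nc1ccc(Br)cc1)Nc1ccc2[nH]ccc2c1` carries a bromo group, and in this assay compound 3 gives 5900 nM, the only single number shown among the three. The step of an at least 5.0-fold lower number from compound 1 to compound 3 (0.70 log units; beyond the scatter) is open-ended, because compound 1 sits at the limit of > 30000 nM in this assay, at which 1 of the 3 values shown sits.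

Compound 4 `CCOC(=O)c1ccc(NC(=S)Nc2ccc3[nH]ccc3c2)cc1` differs from compound 3 by ethoxycarbonyl in place of bromo on an aromatic carbon. Within the data shown here, only the step from compound 1 to compound 3 has been measured, and it concerns a different group, so it gives no direct guide for this exchange. The expected outcome for compound 4 is a step of a 2.0-fold higher number from compound 3 to compound 4 (0.31 log units; beyond the scatter), leaning toward a weaker result. Compound 4 is estimated to give 12000 nM in this assay, with a range from 3000 nM to 50000 nM.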

Compound 4, half-maximal inhibitory concentration: 71000 nM
Estimate against measurement, compound 4: 5.9-fold (0.77 log units) below, and the stated range ends below it.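

Exchanging bromo for ethoxycarbonyl on the aromatic carbon para to a large group gives a 12-fold higher number from compound 3 to compound 4 (1.08 log units; beyond the scatter) in this assay, so the identity of the group at this place matters greatly. Compound 3 had suggested that a group here could lower the number, and compound 4 shows that this does not hold for every group. The step from compound 1 to compound 4 cannot be read, because the value of compound 1 is a limit and not a number: the limit of > 30000 nM in this assay, at which 1 of the 4 values shown sits.

With only hydrogen, hydroxyl, bromo and ethoxycarbonyl shown here, these compounds reveal no trend across groups at this place. As far as these compounds go, whether a chloro group, a methoxy group or a carboxylic acid would behave more like compound 3 or more like compound 4 remains open.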